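A few compounds are considered here, and "the series" means these few. Any claim that something is new, unique, unknown or untested is made for them only; others in the source may bear on it.

Measured so far:
Compound 1 `COc1ccc(-c2cc3cc(C)ccc3c(-c3cccc(O)c3)n2)c(C)c1`: 5510 nM
Compound 2 `COc1ccc(-c2cc3cc(C)ccc3c(-c3cccc(O)c3)n2)cc1OC`: 6510 nM

Both compounds were tested in a functional assay on DU-145 cells (Homo sapiens) for cytotoxicity, read by CCK-8 assay and cell counting, with a stated time of 72 h; a lower number here means a stronger inhibitor, a higher number a weaker inhibitor. Compound 1 gives 5510 nM there, and compound 2 gives 6510 nM. The two numbers lie within the usual scatter of repeated measurements of each other, so neither compound can be called the stronger or weaker of the pair; compound 2 simply has the higher of the two figures.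

Compound 3 `COc1cccc(-c2nc(-c3ccc(OC)c(OC)c3)cc3cc(C)ccc23)c1` has not been measured. It is the same molecule as compound 2 except for one change: methyl in place of hydrogen on an oxygen on an aromatic ring. Put another way, the hydroxy group becomes a methoxy group, so the 3-hydroxyphenyl becomes a 3-methoxyphenyl. For the measured compounds named here, no measured pair shows this exact change, so the expectation rests on the general size of effects seen here. A modest loss of potency, near the edge of the scatter, is expected for compound 3, with a step of a 1.5-fold higher number from compound 2 to compound 3 (0.19 log units; within the scatter) in this assay. The estimate for compound 3 is 10000 nM, with a range from 3500 nM to 30000 nM.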

Compound 3, half-maximal inhibitory concentration: > 50000 nM
Compound 3: only a limit was reported (the forecaster's own chance of this, stated with the estimate: 10%); middle value at least 5.0-fold (0.69 log units) from the limit.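

Changing the hydroxy group of the 3-hydroxyphenyl to a methoxy group gives, in this assay, an at least 7.6-fold higher number from compound 2 to compound 3 (0.88 log units; beyond the scatter). For the compounds shown here, this is the first view of this position, since compounds 1 and 2 both carry the same 3-hydroxyphenyl, and it shows that the number here can respond strongly to a change as small as one methyl on the oxygen. Compound 3 has only a limit and not a number, so the full size of the step stays unknown: the limit of > 50000 nM in this assay, at which 1 of the 3 values shown sits.

The compounds shown leave open whether the hydrogen on that oxygen is what counts, or the size of whatever sits there. An amine in place of the hydroxy group, or a longer chain such as ethoxy on the same oxygen, would help to separate these two readings.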